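Fluorobenzyl for Phenyl at the Fluorinated Piperidine Carbon

The source may report more compounds than this note shows. Statements on the series, on what has been measured and on what is new or still open speak of the compounds shown alone.

Measured compounds:
compound 1 `c1ccc(CC2CCN(CCCc3c[nH]c4ccc(-n5cnnc5)cc34)CC2)cc1`, 0.6 nM
compound 2 `FC1(Cc2ccccc2)CCN(CCCc2c[nH]c3ccc(-n4cnnc4)cc23)CC1`, 0.5 nM

In a functional assay on CHO cells for agonist activity at 5-hydroxytryptamine receptor 1D (Homo sapiens), read by GTPgammaS binding (a lower number here means that less compound is needed, a higher number that more compound is needed for the effect), compound 1 gives 0.6 nM and compound 2 gives 0.5 nM; the step of a 1.2-fold lower number from compound 1 to compound 2 (0.08 log units; within the scatter) is within the scatter, so the two stand together. Compound 3 `Fc1cccc(CCC2(F)CCN(CCCc3c[nH]c4ccc(-n5cnnc5)cc34)CC2)c1` differs from compound 2 by 3-fluorobenzyl in place of phenyl on a saturated chain carbon bound to a saturated ring carbon. For the measured compounds named here, the only measured step concerns fluoro on a saturated ring carbon and does not touch this change, so no measured step bears on it. The number for compound 3 is therefore expected near that of compound 2, estimated at 0.7 nM (range 0.2 nM to 3 nM), a step of a 1.4-fold higher number from compound 2 to compound 3 (0.15 log units; within the scatter), with wide uncertainty in this assay.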

Compound 3, half-maximal effective concentration: 5.1 nM
Compound 3: middle estimate off by 7.3-fold (0.86 log units), on the low side, and the stated range ends below it.
By their numbers in this assay, from the lowest: compounds 2 and 1 (each within the scatter of the next); then compound 3.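

In this assay, for the compounds shown here, the saturated chain carbon bound to a saturated ring carbon proves sensitive to substitution: 3-fluorobenzyl in place of phenyl gives a 10-fold higher number from compound 2 to compound 3 (1.01 log units; beyond the scatter) and is the first change here that moves the number beyond the scatter. The earlier fluoro step, a 1.2-fold lower number from compound 1 to compound 2 (0.08 log units; within the scatter), left compound 1 and compound 2 together. No available evidence accounts for this result.

The compounds shown leave open whether the rise follows from the longer link or the ring fluorine, as compound 3 carries both. As far as these compounds go, whether a plain 2-phenylethyl group or an amine on the ring would restore the number also remains open.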